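A Tert-Butyl Swap Tested for Cytotoxicity in Human Cells

The source may report more compounds than this note shows. Statements on the series, on what has been measured and on what is new or still open speak of the compounds shown alone.

Compound 1 `Cc1cc(NC(=O)Nc2cccc(C(N)=O)c2)c2ccccc2n1`: in an ADME assay on BJ cells (Homo sapiens) for cytotoxicity, with a stated time of 72 h (on this read-out lower numbers stand for an effect already at smaller amounts and higher numbers for an effect only at larger amounts of compound), compound 1 gives > 25000 nM, which is a limit of the assay and not a number.
Compound 2 `COc1cccc(NC(=O)Nc2cc(C)nc3ccccc23)c1`: in this assay compound 2 gives 27000 nM.

Compound 2 holds the only number shown in this assay; the other result is a limit. Among the compounds with values here, the one measured step, a step that the limit leaves unreadable from compound 1 to compound 2, cannot be read in size because compound 1 sits at the limit of > 25000 nM in this assay, at which 1 of the 2 values shown sits. Compound 3 `Cc1cc(NC(=O)Nc2cccc(C(C)(C)C)c2)c2ccccc2n1` differs from compound 2 by tert-butyl in place of methoxy on an aromatic carbon. Within the data shown here, no measured step involves a tert-butyl group, so nothing bears directly on this change, and the sole step available gives no readable size. With no guide toward either direction, the expected step is a 1.1-fold lower number from compound 2 to compound 3 (0.03 log units; within the scatter), meaning no change beyond the usual scatter. Compound 3 is therefore estimated at 25000 nM, with a range from 10000 nM to 60000 nM.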

Compound 3, half-maximal effective concentration: > 25000 nM
Compound 3 was reported as a limit; the forecaster's own chance of this, stated with the estimate: 50%; the middle value lies on the limit itself.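

Compound 3 comes out as a limit and not a number, so the steps linking it to compound 1 and compound 2 cannot be read in size: the limit of > 25000 nM in this assay, at which 2 of the 3 values shown sit.

On these data alone, whether in this assay tert-butyl, methoxy and carbamoyl on this aromatic carbon truly differ stays open.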